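Methyl to Vinyl Repeated on a Different Core

This account rests on a few compounds, and the source may have more. Where it says the series, first, only, none or still open, it means among the compounds named here.

In a functional assay (trachea) with Cavia porcellus as the target (a lower number here means that less compound is needed, a higher number that more compound is needed for the effect), compound 1 `CCCn1c(=O)n(CC)c(=O)c2[nH]cnc21` gives 1300 nM, and compound 2 `C=CCn1c(=O)c2[nH]cnc2n(CCC)c1=O` gives 1600 nM. The change between them, (vinyl in place of methyl on a saturated chain carbon bound to an aromatic nitrogen), made a 1.2-fold higher number from compound 1 to compound 2 (0.09 log units; within the scatter). Compound 3 `CCCn1cnc2c1c(=O)n(C)c(=O)n2CCC` gives 5000 nM, the highest of the three numbers; the difference between its core and the core of compound 1 is not broken down here. Compound 4 `C=CCCn1cnc2c1c(=O)n(C)c(=O)n2CCC` carries the same kind of change on this core: vinyl in place of methyl on a saturated chain carbon, two bonds along the chain from an aromatic nitrogen. The place is not identical, however: in compound 2 the carbon is bound to an aromatic nitrogen, whereas in compound 4 it lies two bonds along the chain from an aromatic nitrogen. Because a 1.2-fold higher number from compound 1 to compound 2 (0.09 log units; within the scatter) stayed within the scatter, compound 4 is expected to give about 5500 nM, between 2500 nM and 12000 nM. The expected step is a 1.1-fold higher number from compound 3 to compound 4 (0.04 log units; within the scatter).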

Compound 4, half-maximal effective concentration: 16800 nM
Beside the measured number, compound 4's estimate is 3.1-fold (0.48 log units) below it, and the stated range ends below it.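

On the core of compound 3 the change gave a 3.4-fold higher number from compound 3 to compound 4 (0.53 log units; beyond the scatter), so in this assay it did not carry over unchanged from the core of compound 1, and the two steps differ: the same change on two cores in this assay, a 1.2-fold higher number (0.09 log units; within the scatter) from compound 1 to compound 2 and a 3.4-fold higher number (0.53 log units; beyond the scatter) from compound 3 to compound 4, 2.7-fold (0.44 log units) apart, beyond the scatter of two such steps

This comparison rests on one pair per core, and the place also differs: the vinyl in compound 2 stands on a saturated chain carbon bound to an aromatic nitrogen, while that in compound 4 stands two bonds along the chain from one. The gap therefore cannot be assigned to the core alone, and it shows nothing about any further core.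

The compounds shown leave open whether an allyl group on the core of compound 3 would repeat either step. They also leave open how a butyl chain, an amine or a carboxylic acid in place of the but-3-en-1-yl group would read in this assay.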